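Two chlorines on the shared core: expected growth inhibition

The source may report more compounds than this note shows. Statements on the series, on what has been measured and on what is new or still open speak of the compounds shown alone.

Four compounds share one core carried on a benzyl group bearing a chloromethyl arm. Compound 1 is `ClCc1ccccc1Cn1cnc2c(Cl)nc(Cl)nc21`, compound 2 is `ClCc1ccccc1Cn1cnc2c(Cl)ncnc21`, compound 3 is `ClCc1cccc(Cn2cnc3c(Cl)ncnc32)c1` and compound 4 is `ClCc1cccc(Cn2cnc3c(Cl)nc(Cl)nc32)c1`. They were tested in a functional assay on PC-3 cells (Homo sapiens) for cytotoxicity, read by sulforhodamine B assay, with a stated time of 48 h; on this read-out higher numbers stand for weaker inhibition of growth and lower numbers for stronger inhibition of growth. In this assay compound 1 gives 1620 nM, compound 2 gives 10500 nM and compound 3 gives 18200 nM. Compound 4 has not been measured.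

Compound 2 and compound 1 differ in one place: chloro in place of hydrogen on an aromatic carbon. That change produced a 6.5-fold lower number from compound 2 to compound 1 (0.81 log units; beyond the scatter), a step beyond the scatter of repeated measurements. Compound 3 and compound 2 are built from the same atoms joined differently, and the difference between the two cores is not broken down here; their values sit within the scatter of each other.

Compound 4 stands to compound 3 exactly as compound 1 stands to compound 2: chloro in place of hydrogen on an aromatic carbon. The surroundings of the change are described in the same words for both pairs, so this is the same change. Compound 4 is therefore expected to give 3000 nM, with the number estimated to fall somewhere from 1200 nM to 8000 nM. That expectation rests on the earlier step of a 6.5-fold lower number from compound 2 to compound 1 (0.81 log units; beyond the scatter), so the estimated change amounts to a 6.1-fold lower number from compound 3 to compound 4 (0.78 log units; beyond the scatter). Whether the second chlorine behaves the same on the other benzyl arrangement remains to be seen.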

Compound 4, concentration for total growth inhibition: 5010 nM
Beside the measured number, compound 4's estimate is 1.7-fold (0.22 log units) below it, and the stated range covers the measured number.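

In this assay, placing chloro instead of hydrogen on the aromatic carbon between two ring nitrogen atoms gives a 3.6-fold lower number from compound 3 to compound 4 (0.56 log units; beyond the scatter), so the second chlorine again goes with stronger inhibition of growth on the other benzyl arrangement. The change therefore points the same way on both cores, and the sizes of its two steps cannot be told apart: the same change on two cores in this assay, a 6.5-fold lower number (0.81 log units; beyond the scatter) from compound 2 to compound 1 and a 3.6-fold lower number (0.56 log units; beyond the scatter) from compound 3 to compound 4, 1.8-fold (0.25 log units) apart, within the scatter of two such steps

This supports carrying the change between these two closely related cores in this one assay, but two pairs are a small sample: they do not show that the two steps are truly equal, that the change would behave alike on a different core, or why the number falls.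

The compounds shown leave open what other groups on that same aromatic carbon would do, since only hydrogen and chloro appear there; an amine, a methoxy group or a bromine atom would test how much depends on chloro itself. They also leave open whether the step survives when the chloromethyl arm gives way to a hydroxymethyl group or a longer chain.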